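This account rests on a few compounds, and the source may have more. Where it says the series, first, only, none or still open, it means among the compounds named here.

Within the data shown here, in a functional assay on SK-MEL-28 cells (Homo sapiens) for inhibition, read by colorimetric assay and MTT assay, with a stated time of 72 h (a lower number here means a stronger inhibitor, a higher number a weaker inhibitor), compound 1 `C=CCCCCOc1ccccc1-c1cnc(OCCC=C)n1C` gives 17000 nM, which places it at the low end of the three numbers so far, level with compound 3 `C=CCCOc1ncc(-c2ccccc2OC)n1C` at 21000 nM. Compound 2 `C=CCCCCOc1ccc(OC)cc1-c1cnc(OCCC=C)n1C` gives 62000 nM.

The next compound, compound 4 `C=CCCCCOc1ccccc1-c1cnc(OC)n1C`, changes compound 1 by hydrogen in place of allyl on a saturated chain carbon bound to an oxygen on an aromatic ring. Put simply, a but-3-en-1-yl chain is cut back to methyl, so (but-3-en-1-yl)oxy becomes methoxy.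

The closest guide is compound 3, where hydrogen replaces pent-4-en-1-yl at the same kind of place, on the other chain. That step is a 1.2-fold higher number from compound 1 to compound 3 (0.09 log units; within the scatter). The step to compound 2 is a different change, methoxy in place of hydrogen on an aromatic carbon, and it is larger: a 3.6-fold higher number from compound 1 to compound 2 (0.56 log units; beyond the scatter). It shows only that modest shifts occur in this small set.

With a single close precedent, little movement is expected in this assay, and the expected step, a 1.5-fold higher number from compound 1 to compound 4 (0.17 log units; within the scatter), is a slight rise. For compound 4 the estimated value is 25000 nM, with an expected range from 9000 nM to 70000 nM.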

Compound 4, half-maximal inhibitory concentration: 85000 nM
Compound 4: the middle estimate sits 3.4-fold (0.53 log units) below what was measured; the measured number lies above the stated range.
By their numbers in this assay, from the lowest: compounds 1 and 3 (each within the scatter of the next); then compounds 2 and 4 (each within the scatter of the next).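

Cutting the but-3-en-1-yl chain back to methyl makes compound 4 a weaker inhibitor in this assay, with a 5.0-fold higher number from compound 1 to compound 4 (0.70 log units; beyond the scatter), so at this position the chain's length is tied to a real change in the number. The matching cut on the other chain, where pent-4-en-1-yl is lost, gives only a 1.2-fold higher number from compound 1 to compound 3 (0.09 log units; within the scatter), so the two chains of compound 1 cannot be treated as interchangeable. Nothing available here explains why shortening one chain shifts the number and shortening the other does not.

Only but-3-en-1-yl and methyl are shown at this position, so the compounds leave open how the number moves with an ethyl or propyl chain in between. They also leave open whether the double bond matters, which a saturated butyl chain would test, and whether a longer chain would lower the number further.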